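Chain shortening from compound 2 to compound 4

The source may hold more compounds than are shown below. What is called first, only, known or untested is meant among the compounds shown, and "the series" means these compounds.

Measured so far in a functional assay on MCF7 cells (Homo sapiens) for inhibition, read by MTT assay, with a stated time of 72 h; on this read-out lower numbers stand for stronger inhibition and higher numbers for weaker inhibition:
- compound 1 `CNC(=O)CCCCCCCn1nc(-c2ccc3oc(N)nc3c2)c2c(N)ncnc21` gives 7220 nM.
- compound 2 `Nc1ncnc2c1c(-c1cnc3[nH]ccc3c1)nn2CCCC(=O)NO` gives only a limit, > 150000 nM.
- compound 3 `Nc1nc2cc(-c3nn(CCCC(=O)NO)c4ncnc(N)c34)ccc2o1` gives only a limit, > 50000 nM.

Compound 2 thus stands at a limit in this assay and has no number of its own. Among the compounds with values here, of the three values shown, one sits at the limit of > 150000 nM in this assay, at which 1 of the 3 values shown sits, and one at the limit of > 50000 nM in this assay, at which 1 of the 3 values shown sits, so compound 1 carries the only numbered value of the set.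

Compound 4 `Nc1ncnc2c1c(-c1cnc3[nH]ccc3c1)nn2CCC(=O)NO` differs from compound 2 by hydroxycarbamoyl in place of (hydroxycarbamoyl)methyl on a saturated chain carbon, two bonds along the chain from an aromatic nitrogen. Within the data shown here, no measured step carries the same change. Among the measured compounds shown here, the only step available, an at least 6.9-fold higher number from compound 1 to compound 3 (0.84 log units; beyond the scatter), involves a different chain and also ends at a limit, so it bears on compound 4 only loosely; it shows that a short chain ending in hydroxycarbamoyl can sit beyond the range of this assay.

Because compound 2 already gives > 150000 nM, no movement beyond the scatter can be resolved from it. The step from compound 2 to compound 4 is therefore expected to be a number no higher from compound 2 to compound 4 (the limit leaves the size open), with a high chance that only a limit is reported. Compound 4 is estimated at 150000 nM, within 50000 nM to 400000 nM.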

Compound 4, half-maximal inhibitory concentration: > 150000 nM
Compound 4: only a limit was reported; the forecaster's own chance of this, stated with the estimate: 80%; the middle value lies on the limit itself.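

In this assay compound 2 and compound 4 each give only a limit, so no step between them can be read; both sit at the same one: the limit of > 150000 nM in this assay, at which 2 of the 4 values shown sit.

Left open is how 3-(hydroxycarbamoyl)propyl in compound 2 and 2-(hydroxycarbamoyl)ethyl in compound 4 compare in inhibition.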